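Shortening the Chain on an Amide Nitrogen

The compounds below may be only part of what the source reports. "The series", "measured", "known", "first", "only" and "open" are said of these compounds alone.

Of the compounds shown here, two have been measured in an assay on HEK293 cells for agonist activity at transient receptor potential cation channel subfamily M member 8 (Homo sapiens), read by fluorescence and calcium flux, with a stated time of 15 min; on this read-out higher numbers stand for an effect only at larger amounts of compound and lower numbers for an effect already at smaller amounts. Compound 1 `COc1ccc2oc(C(=O)N(Cc3cccs3)c3ccn[nH]3)cc2c1` gives 1.1 nM in this assay. Compound 2 `Cc1ccc(OCC(=O)N(Cc2cccs2)CC(C)C)cc1` gives 900 nM, the highest of the two numbers; its nearest neighbour is compound 1, whose number is far lower, a gap well beyond the usual scatter. Among the measured compounds shown here, no pair among the measured compounds differs in only one place, so no single step has been measured, and the large gap between compound 1 and compound 2 cannot be tied to any one change.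

Compound 3 `Cc1ccc(OCC(=O)N(C)Cc2cccs2)cc1` has not yet been measured. It differs from compound 2 in one place: hydrogen in place of isopropyl on a saturated chain carbon bound to an amide-type nitrogen. This shortens the chain on the amide-type nitrogen and leaves the rest of compound 2 untouched. For the measured compounds named here, nothing among the measured compounds shows what such a shortening does here, so the expectation rests on the change alone. The step of a 3.3-fold higher number from compound 2 to compound 3 (0.52 log units; beyond the scatter) is expected to raise the number modestly, likely beyond the scatter, meaning an effect only at somewhat larger amounts. Compound 3 is expected to give 3000 nM, with a range from 800 nM to 12000 nM.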

Compound 3, half-maximal effective concentration: 400 nM
For compound 3 the middle estimate is 7.5-fold (0.88 log units) above the measured one, and the stated range ends above it.
By their numbers in this assay, from the lowest: compound 1; then compound 3; then compound 2.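

Among the compounds shown here, this is the first change in a single place that can be read here: putting hydrogen in place of isopropyl on a saturated chain carbon bound to an amide-type nitrogen, which also reads as isobutyl to methyl, gives in this assay a 2.3-fold lower number from compound 2 to compound 3 (0.35 log units; beyond the scatter). The direction matters more than the modest size: with the chain cut down to methyl, the effect appears at smaller amounts of compound, so on this pair the isobutyl chain is not needed for activity, and the shorter chain does somewhat better. Nothing at hand explains why the number moves this way, so the result stands as an observation about these two compounds only.

On these data alone, two points on a chain do not make a trend, so it remains open whether an ethyl or propyl chain would fall between methyl and isobutyl, or whether the number would keep falling with hydrogen alone on the amide-type nitrogen. Also open, as far as these compounds go, is how this position would respond to a group of a different kind, such as an amine or a carboxylic acid at the end of a longer chain.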